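The compounds below may be only part of what the source reports. "The series", "measured", "known", "first", "only" and "open" are said of these compounds alone.

Measured so far:
compound 1 `CC1(C)S[C@@H]2/C(=C\C(=O)c3ccco3)C(=O)N2[C@H]1C(=O)OC(c1ccccc1)c1ccccc1` gives 61500 nM in a functional assay on NCI-H1299 cells (Homo sapiens) for cytotoxicity, read by MTT assay, with a stated time of 48 h; on this read-out lower numbers stand for stronger inhibition and higher numbers for weaker inhibition;
compound 2 `CC1(C)[C@H](C(=O)OC(c2ccccc2)c2ccccc2)N2C(=O)/C(=C/C(=O)c3ccccc3)[C@H]2S1(=O)=O` gives 50100 nM in this assay.

Compound 1 holds the highest of the two numbers in this assay; its nearest neighbour is compound 2, and the two values lie within the usual scatter of each other, so no order between them can be read. For the measured compounds named here, no pair of measured compounds differs in a single place, and compound 1 and compound 2 are separated by more than one change, so no calibrated step is available.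

Compound 3 `CC1(C)S[C@@H]2/C(=C\C(=O)c3ccc(F)cc3)C(=O)N2[C@H]1C(=O)OC(c1ccccc1)c1ccccc1` keeps the core of compound 1 and differs from it in one place: 4-fluorophenyl in place of furan-2-yl on a carbonyl carbon. Nothing in the measured set isolates a change of this kind. Both measured compounds sit in the same weak region of this assay, which gives no ground for expecting a shift beyond the scatter in either direction. The expected step is a 1.2-fold lower number from compound 1 to compound 3 (0.09 log units; within the scatter). Compound 3 is estimated at 50000 nM, with a range from 18000 nM to 140000 nM.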

Compound 3, half-maximal inhibitory concentration: 25200 nM
The estimate for compound 3 lay 2.0-fold (0.30 log units) above the measured number; measured number inside the range.
By their numbers in this assay, from the lowest: compounds 3, 2 and 1 (each within the scatter of the next, the first and the last beyond it).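

In this assay, for the compounds shown here, 4-fluorophenyl in place of furan-2-yl on a carbonyl carbon gives a 2.4-fold lower number from compound 1 to compound 3 (0.39 log units; beyond the scatter) and is the first single change with a reading at all. This position is therefore not silent: the group on the carbonyl carbon can move the number, although the size of the step is modest and compound 3 at 25200 nM remains a weak member of the series. No measurement at hand accounts for the shift.

Open, from the compounds shown here alone, is whether the fluorine or the six-membered ring carries the step, and compound 2 cannot settle this, as it differs from compound 3 in more than one place. Also open, going by these compounds, is how an amine or a carboxylic acid on the aromatic ring, or a longer chain in its place, would read in this assay on the core of compound 1.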